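A halogenated anilino ring in place of a dimethoxy one

The compounds below may be only part of what the source reports. "The series", "measured", "known", "first", "only" and "open" are said of these compounds alone.

Compound 3 `COc1cc(Nc2nc(SCc3ccc(C(F)(F)F)cc3)nc3ccccc23)cc(OC)c1` gives 16100 nM in a functional assay on MDA-MB-231 cells (Homo sapiens) for cytotoxicity, read by MTT assay, with a stated time of 72 h; on this read-out lower numbers stand for stronger inhibition and higher numbers for weaker inhibition. Compound 1 `CCOc1ccc(Nc2nc(SCc3ccc(C(F)(F)F)cc3)nc3ccccc23)cc1` gives 23000 nM in this assay, and a 1.4-fold lower number from compound 1 to compound 3 (0.15 log units; within the scatter). For compound 2 `COc1ccc(Nc2nc(SCc3ccc(C(F)(F)F)cc3)nc3ccccc23)c(OC)c1` this assay reports only a limit, > 50000 nM. Of the two numbers, compound 3 gives the lower one, though its gap to compound 1 lies within the scatter. Compound 4 `Fc1ccc(Nc2nc(SCc3ccc(C(F)(F)F)cc3)nc3ccccc23)cc1Cl` differs from compound 3 by 3-chloro-4-fluorophenyl in place of 3,5-dimethoxyphenyl on a nitrogen on an aromatic ring. For the measured compounds named here, no measured step exchanges a dimethoxyphenyl for a halogenated phenyl; the known steps, an at least 2.1-fold higher number from compound 1 to compound 2 (0.33 log units; beyond the scatter) and an at least 3.1-fold lower number from compound 2 to compound 3 (0.49 log units; beyond the scatter), only rearrange methoxy groups, and both rest on a limit (the limit of > 50000 nM in this assay, at which 1 of the 3 values shown sits). The step is therefore expected to be small, a 1.1-fold lower number from compound 3 to compound 4 (0.03 log units; within the scatter). Compound 4 is estimated at 15000 nM, between 5000 nM and 50000 nM.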

Compound 4, half-maximal inhibitory concentration: 14500 nM
Compound 4: the middle estimate sits 1.0-fold (0.01 log units) above what was measured; low and high end bracket the measured number.
By their numbers in this assay, from the lowest: compounds 4, 3 and 1 (each within the scatter of the next). At a limit, above all of these: compound 2.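

Replacing 3,5-dimethoxyphenyl with 3-chloro-4-fluorophenyl on a nitrogen on an aromatic ring removes the hydrogen-bond acceptors from this group, yet this assay shows only a 1.1-fold lower number from compound 3 to compound 4 (0.05 log units; within the scatter). Against 4-ethoxyphenyl, the same group gives a 1.6-fold lower number from compound 1 to compound 4 (0.20 log units; within the scatter), so this position accepts halogen or alkoxy substituents without a change beyond the scatter. Only 2,4-dimethoxyphenyl stands apart, with an at least 3.4-fold lower number from compound 2 to compound 4 (0.53 log units; beyond the scatter), a step that rests on a limit: the limit of > 50000 nM in this assay, at which 1 of the 4 values shown sits.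

The compounds shown leave open whether an amine or a carboxylic acid on this phenyl ring would shift the number beyond the scatter.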